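Swapping Oxolan-2-yl for Allyl at the Aromatic Nitrogen

The source may hold more compounds than are shown below. What is called first, only, known or untested is meant among the compounds shown, and "the series" means these compounds.

Three compounds have been tested in a functional assay on MCF7 cells (Homo sapiens) for antiproliferative activity; on this read-out higher numbers stand for weaker inhibition and lower numbers for stronger inhibition:

Compound 1 `CC[C@H](C)Cn1c(Cc2cc(OC)c(OC)c(OC)c2)nc2c(N)nc(F)nc21`: 43700 nM
Compound 2 `C#CCCCn1c(Cc2cc(OC)c(OC)c(OC)c2)nc2c(N)nc(F)nc21`: 11000 nM
Compound 3 `COc1cc(Cc2nc3c(N)nc(F)nc3n2CC2CCCO2)cc(OC)c1OC`: 22900 nM

Compound 3 stands second highest of the three. Its gap to compound 1 is within the scatter, since a 1.9-fold lower number from compound 1 to compound 3 (0.28 log units; within the scatter), whereas a 2.1-fold higher number from compound 2 to compound 3 (0.32 log units; beyond the scatter) is a modest step beyond it. Compound 4 `C=CCCn1c(Cc2cc(OC)c(OC)c(OC)c2)nc2c(N)nc(F)nc21` differs from compound 3 in one place: allyl in place of oxolan-2-yl on a saturated chain carbon bound to an aromatic nitrogen. Allyl, like the but-3-yn-1-yl of compound 2, is an open unsaturated chain without a ring or a hydrogen-bond acceptor, so the step of a 2.1-fold higher number from compound 2 to compound 3 (0.32 log units; beyond the scatter), run in reverse, is the closest guide; a 4.0-fold lower number from compound 1 to compound 2 (0.60 log units; beyond the scatter) points the same way. A modest lower number is therefore expected. Compound 4 is estimated at 14000 nM, in the range 5000 nM to 40000 nM, which would mean an expected 1.6-fold lower number from compound 3 to compound 4 (0.21 log units; within the scatter).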

Compound 4, half-maximal inhibitory concentration: 33100 nM
For compound 4 the middle estimate is 2.4-fold (0.37 log units) below the measured one, within the range that was stated.
By their numbers in this assay, from the lowest: compound 2; then compounds 3, 4 and 1 (each within the scatter of the next).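

On the saturated chain carbon bound to an aromatic nitrogen, allyl cannot be told apart from oxolan-2-yl (a 1.4-fold higher number from compound 3 to compound 4 (0.16 log units; within the scatter)) or from sec-butyl (a 1.3-fold lower number from compound 1 to compound 4 (0.12 log units; within the scatter)). Removing the ring and its hydrogen-bond acceptor therefore produces no readable change here. The clear contrast is between the two unsaturated chains (a 3.0-fold higher number from compound 2 to compound 4 (0.48 log units; beyond the scatter)), so but-3-en-1-yl cannot stand in for but-3-yn-1-yl at this position.

From the compounds shown here alone, whether an amine, a carboxylic acid or a longer chain ending in a triple bond would shift the number remains open. No available evidence explains the difference between the two unsaturated chains.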